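Replacing the phenyl of compound 2 with a butyl chain

This account rests on a few compounds, and the source may have more. Where it says the series, first, only, none or still open, it means among the compounds named here.

Measured so far:
compound 1, `CCC(c1ccccc1)N(CC)c1nc(-c2ccc(Cl)cc2OC)n(C)n1`, 150 nM
compound 2, `CCCN(c1nc(-c2ccc(Cl)cc2OC)n(C)n1)C(CC)c1ccccc1`, 26 nM

The two measured compounds share one core and differ only in the chain on the nitrogen. In an in vitro assay on Ltk- cells for binding affinity to corticotropin-releasing factor receptor 1 (Homo sapiens) (a higher number here means a weaker inhibitor, a lower number a stronger inhibitor), compound 1 gives 150 nM. Compound 2 carries a propyl in place of the ethyl, and the step of a 5.8-fold lower number from compound 1 to compound 2 (0.76 log units; beyond the scatter) is the only one recorded. Compound 2 therefore stands at the lowest of the two numbers, with compound 1 its nearest neighbour.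

Compound 3, `CCCCC(CC)N(CCC)c1nc(-c2ccc(Cl)cc2OC)n(C)n1`, has not been measured. Its difference from compound 2 is butyl in place of phenyl on a saturated chain carbon bound to a nitrogen on an aromatic ring and a saturated chain carbon. Among the measured compounds shown here, the single measured step concerns a different place, the chain on the nitrogen rather than the carbon that bears the phenyl, so it does not bear on this change, and there is no measured pair in which a phenyl gives way to a butyl. What compound 2 shows is taken as the starting point, and a step of a 1.2-fold lower number from compound 2 to compound 3 (0.07 log units; within the scatter) within the scatter is expected. For compound 3 a value of 22 nM is estimated, between 6 nM and 80 nM.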

Compound 3, inhibition constant: 46 nM
Compound 3: middle estimate off by 2.1-fold (0.32 log units), on the low side, and the stated range covers the measured number.
By their numbers in this assay, from the lowest: compounds 2 and 3 (each within the scatter of the next); then compound 1.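

In this assay, the exchange of the 1-phenylpropyl for the 1-ethylpentyl gives a 1.8-fold higher number from compound 2 to compound 3 (0.25 log units; within the scatter), so in this pair the six-membered aromatic ring of carbon only can give way to an open butyl chain without a difference that can be told from the scatter. Among the compounds shown here, this is the first reading at this place, on a saturated chain carbon bound to a nitrogen on an aromatic ring and a saturated chain carbon; the earlier step showed only that the chain on the nitrogen can move the number beyond the scatter. Nothing at hand explains why the two groups read alike here.

The compounds shown leave open how far this tolerance extends, since a single pair cannot say whether a cyclohexyl ring, a shorter propyl chain or a chain carrying an ether oxygen such as methoxyethyl would also read alike at this carbon. They also leave open whether the same exchange would read the same way with the ethyl on the nitrogen that compound 1 carries in place of the propyl.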